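Swapping chloro for methyl on a shared core

This account rests on a few compounds, and the source may have more. Where it says the series, first, only, none or still open, it means among the compounds named here.

Of the compounds shown here, three have been tested in an ADME assay on microsomes from liver (Rattus norvegicus) for metabolic stability; on this read-out lower numbers stand for a shorter-lived compound and higher numbers for a longer-lived compound. Compound 1, `CC#C[C@@H](Cc1nnn[nH]1)c1ccc(OCc2cc(Cl)c3scc(-c4ccccc4C)c3c2)cc1`, gives 0.117 h. Compound 2, `CC#C[C@@H](Cc1nnn[nH]1)c1ccc(OCc2ccc3sc(Cl)c(-c4ccccc4C)c3c2)cc1`, gives 1.08 h, and compound 3, `CC#C[C@@H](Cc1nnn[nH]1)c1ccc(OCc2ccc3sc(C)c(-c4ccccc4C)c3c2)cc1`, gives 0.483 h. Compound 1 and compound 2 are built from the same atoms joined differently; the difference between the two cores is not broken down here. Among the three, compound 1 stands lowest, and its gaps to compound 3 and to compound 2 both lie beyond the usual scatter of this assay.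

Compound 3 differs from compound 2 by methyl in place of chloro on an aromatic carbon. This step, a 2.2-fold lower number from compound 2 to compound 3 (0.35 log units; beyond the scatter), is modest but beyond the scatter. The unmeasured compound 4, `CC#C[C@@H](Cc1nnn[nH]1)c1ccc(OCc2cc(C)c3scc(-c4ccccc4C)c3c2)cc1`, differs from compound 1 by methyl in place of chloro on an aromatic carbon. It is the same kind of change, but not the same: in compound 3 the methyl sits on a five-membered aromatic ring with one sulfur, next to the ring sulfur and next to the ring atom that bears a 2-methylphenyl group, whereas in compound 4 it sits on a six-membered aromatic ring of carbon only, ortho to a fused ring, meta to a fused ring and meta to a large group.

Going by the values given here, because the only comparable step is a 2.2-fold lower number from compound 2 to compound 3 (0.35 log units; beyond the scatter), and its place differs, the expectation for compound 4 is a step of about a 1.7-fold lower number from compound 1 to compound 4 (0.22 log units; within the scatter) in this assay, taken with caution. Compound 4 is therefore estimated at 0.07 h, with a likely range from 0.03 h to 0.25 h.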

Compound 4, half-life: < 0.0667 h
Compound 4 ended at the assay's limit; the forecaster's own chance of this, stated with the estimate: 10%; at least 1.0-fold (0.02 log units) between middle value and limit.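

In this assay compound 4 gives < 0.0667 h, which is a limit of the assay and not a measured number. On the core of compound 1, methyl in place of chloro therefore gives an at least 1.7-fold lower number from compound 1 to compound 4 (0.24 log units; that floor lies within the scatter), so the change points the same way on both cores, although this figure marks only the smallest step the limit allows and the true step could be larger. This shows that the direction seen on the first core was not contradicted on the second, but it does not show that the size of the step carries over, and a single pair on each core would be thin support for a rule in any case: the same change on two cores in this assay, a 2.2-fold lower number (0.35 log units; beyond the scatter) from compound 2 to compound 3 and an at least 1.7-fold lower number (0.24 log units; that floor lies within the scatter) from compound 1 to compound 4; the limit leaves it open whether they differ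

The compounds shown compare chloro only with methyl, so it stays open how a fluoro, a trifluoromethyl or a nitrile group would read on either core, and whether any of them would keep the half-life closer to that of the chloro compounds. On these data alone, it also stays open how the plain hydrogen would read at these places, which would show whether chloro and methyl each lengthen or shorten the half-life relative to having no group there at all.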